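The compounds below may be only part of what the source reports. "The series", "measured", "known", "first", "only" and "open" are said of these compounds alone.

Measured in an ADME assay on HEK-293T cells (Homo sapiens) for inhibition, read by CCK-8 assay, with a stated time of 48 h, tested at 20 uM; a higher number here means more inhibition of growth at the concentration tested, a lower number less inhibition of growth:

- Compound 1 `COc1ccc(Cc2nnc(NC(=O)/C(C#N)=C/c3ccccc3OS(=O)(=O)c3ccc([N+](=O)[O-])cc3)s2)cc1`: 17%
- Compound 2 `N#C/C(=C\c1ccccc1OS(=O)(=O)c1ccc([N+](=O)[O-])cc1)C(=O)Nc1nnc(Cc2ccc(F)cc2)s1`: 8%
- Compound 3 `Cc1ccc(S(=O)(=O)Oc2ccccc2/C=C(\C#N)C(=O)Nc2nnc(Cc3cccc(F)c3)s2)cc1`: 9%

At 9%, compound 3 lies within the usual scatter of both other compounds. Compound 4 `N#C/C(=C\c1ccccc1OS(=O)(=O)c1ccc([N+](=O)[O-])cc1)C(=O)Nc1nnc(Cc2cccc(F)c2)s1` comes from compound 3 by one change, nitro in place of methyl on an aromatic carbon. Within the data shown here, no measured step makes this exact change. The only one, a number 9 percentage points lower from compound 1 to compound 2 (within the scatter), is fluoro in place of methoxy and stays within the scatter. The nitro group is already present in compound 1 at 17% and compound 2 at 8%, and neither value stands apart from compound 3. The expected step, a number 2 percentage points higher from compound 3 to compound 4 (within the scatter), is therefore none beyond the scatter. For compound 4 the estimate is 11%, with an expected range of 2% to 22%.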

Compound 4, percent growth inhibition at one concentration: "not toxic" (no number reported)
Nothing numeric was reported for compound 4; the estimate stays without a comparison.
By their numbers in this assay, from the lowest: compounds 2, 3 and 1 (each within the scatter of the next).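

Among these compounds, compound 4 is reported in this assay only as "not toxic", without a number, so no step from compound 3 to compound 4 can be read. No measured evidence bears on this result. On these data alone, what nitro in place of methyl does to growth inhibition stays open.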